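Swapping the aryl ring on the oxalamide: compound 4 predicted

This account rests on a few compounds, and the source may have more. Where it says the series, first, only, none or still open, it means among the compounds named here.

Compound 1 `Cc1nc(C(NC(=O)C(=O)Nc2ccc(F)c(F)c2)C2CCCCN2)sc1CO` gives > 87000 nM in an ADME assay on TZM-b1 cells (Homo sapiens) for cytotoxicity, read by XTT assay, with a stated time of 3 days (a higher number here means that more compound is tolerated, a lower number that less compound is tolerated), a limit of the assay rather than a number.
Compound 2 `Cc1nc(C(NC(=O)C(=O)Nc2ccc(F)cc2)C2CCCCN2)sc1CCO` gives > 88000 nM in this assay, again a limit.
Compound 3 `Cc1ccc(NC(=O)C(=O)NC(c2nc(C)c(CO)s2)C2CCCCN2)cc1F` gives > 88000 nM in this assay, also a limit.

All three measured compounds share one core, and none of them gives a number in this assay: each sits at a limit. Compound 2 therefore stands at the top of what the assay can report, alongside the other two, and nothing separates them. Within the data shown here, the only step between measured compounds that differ in one place, a step that the two limits leave unreadable from compound 1 to compound 3, is unreadable for the same reason, so it gives no measure of how a change on the aromatic ring moves the read-out.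

Compound 4 `Cc1nc(C(NC(=O)C(=O)Nc2ccc(Cl)c(F)c2)C2CCCCN2)sc1CCO` differs from compound 2 by 4-chloro-3-fluorophenyl in place of 4-fluorophenyl on an amide-type nitrogen. Among the measured compounds shown here, no measured step bears on this change, and the single step available cannot be read. With every measured value at a limit, the expectation is that compound 4 behaves no differently from compound 2, and the step is estimated as a number no higher from compound 2 to compound 4 (the limit leaves the size open), nothing beyond the scatter. Compound 4 is thus estimated at 88000 nM, within 40000 nM to 88000 nM, most likely again reported as a limit.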

Compound 4, half-maximal cytotoxic concentration: 61000 nM
Estimate against measurement, compound 4: 1.4-fold (0.16 log units) above, and the stated range covers the measured number.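

Compound 4 is the first of the compounds shown to give a number in this assay: compound 4 gives 61000 nM. The group on this amide-type nitrogen is thus a place where the read-out can come off the limit. Among these compounds, the change to 4-chloro-3-fluorophenyl in place of 4-fluorophenyl gives an at least 1.4-fold lower number from compound 2 to compound 4 (0.15 log units; that floor lies within the scatter), while the one step among the earlier compounds cannot be read, which makes this the first step with any readable size, though only as a floor. Only a floor can be stated, and the real size of the step stays unknown, because the starting compound stands at a limit of the assay: the limit of > 88000 nM in this assay, at which 2 of the 4 values shown sit.

The compounds shown do not separate the added chlorine from the added fluorine, so it stays open whether 4-chlorophenyl or 3-fluorophenyl on this nitrogen would alone give a number or stay at the limit. It also stays open what a larger halogen such as bromine, or a group such as trifluoromethyl or methoxy, would do at this position, and why the read-out responds to this change at all.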